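Methyl in place of fluoro: from compound 3 to compound 4

The source may hold more compounds than are shown below. What is called first, only, known or untested is meant among the compounds shown, and "the series" means these compounds.

Compound 3 `NS(=O)(=O)c1ccc(N2N=C(c3ccc(F)cc3)CC2c2cn(-c3ccccc3)nc2-c2ccc(F)cc2)cc1` stands at the upper edge of what has been seen in an ADME assay on Vero cells (Chlorocebus sabaeus) for cytotoxicity, read by MTT assay, with a stated time of 72 h; a lower number here means that less compound is tolerated, a higher number that more compound is tolerated: in this assay compound 3 gives > 753000 nM, which is a limit of the assay and not a number. Compound 1 `NS(=O)(=O)c1ccc(N2N=C(c3ccc(F)cc3)CC2c2cn(-c3ccccc3)nc2-c2ccccc2)cc1` likewise ends at a limit, giving > 807000 nM in this assay. Compound 2 `NS(=O)(=O)c1ccc(N2N=C(c3ccc(Br)cc3)CC2c2cn(-c3ccccc3)nc2-c2ccc(F)cc2)cc1` gives 49400 nM in this assay. Among the measured compounds shown here, the only readable step is an at least 15-fold higher number from compound 2 to compound 3 (1.18 log units; beyond the scatter); the step that the two limits leave unreadable from compound 1 to compound 3 cannot be sized, as the evidence the limit of > 753000 nM in this assay, at which 1 of the 3 values shown sits, and the limit of > 807000 nM in this assay, at which 1 of the 3 values shown sits, shows both ends sitting at limits.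

Compound 4 `Cc1ccc(C2=NN(c3ccc(S(N)(=O)=O)cc3)C(c3cn(-c4ccccc4)nc3-c3ccc(F)cc3)C2)cc1` differs from compound 3 by methyl in place of fluoro on an aromatic carbon, on the same 4-fluorophenyl group that the bromo-to-fluoro exchange touched. For the measured compounds named here, no measured step replaces fluoro with methyl, so the expectation rests on compound 2 alone, whose 49400 nM shows that a larger group on this position can bring the number well down into the readable range. The step of an at least 2.5-fold lower number from compound 3 to compound 4 (0.39 log units; beyond the scatter) is therefore expected to run downward, but compound 4 is estimated to stay far from the number of compound 2, at about 300000 nM, between 70000 nM and 800000 nM.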

Compound 4, half-maximal cytotoxic concentration: > 90600 nM
Compound 4 ended at the assay's limit (the forecaster's own chance of this, stated with the estimate: 30%); the middle value does not contradict the limit.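

In this assay compound 4 gives > 90600 nM, which is a limit of the assay and not a number. Both ends of the step from compound 3 to compound 4 are limits, so that step cannot be read, and this exchange on the aromatic carbon gives no size for methyl against fluoro. Against the bromo analogue the reading is an at least 1.8-fold higher number from compound 2 to compound 4 (0.26 log units; that floor lies within the scatter), so methyl is not yet separated from bromo at this position, whereas fluoro is, with an at least 15-fold higher number from compound 2 to compound 3 (1.18 log units; beyond the scatter).

As far as these compounds go, whether the 4-methylphenyl compound sits nearer the 4-fluorophenyl compound or the bromo compound stays open until a number replaces the limit. Also open, from the compounds shown here alone, is what an amine or a carboxylic acid on this aromatic carbon would give in this assay.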